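The compounds below may be only part of what the source reports. "The series", "measured", "known", "first", "only" and "open" are said of these compounds alone.

Measured in a functional assay on the whole organism for inhibition, with Scenedesmus acutus as the target, with a stated time of 48 h; a higher number here means a weaker inhibitor, a lower number a stronger inhibitor:
Compound 1 `CC(Cl)/C=C/C(=O)N(Cc1ccc(C#N)cc1)CC(C)C`: 398 nM
Compound 2 `CC(Cl)/C=C/C(=O)N(Cc1ccc(Cl)cc1)CC(C)C`: 263 nM

Compound 2 stands at 263 nM, within the scatter of compound 1 at 398 nM. Compound 3 `CC(Cl)/C=C/C(=O)N(Cc1ccc(S(C)(=O)=O)cc1)CC(C)C` follows from compound 2 by methylsulfonyl in place of chloro on an aromatic carbon. Within the data shown here, one measured step bears on this place, a 1.5-fold lower number from compound 1 to compound 2 (0.18 log units; within the scatter), with chloro in place of cyano, and it stays within the scatter. From the compounds shown here alone, no step beyond the scatter is therefore expected in this assay, though the new group remains untested. The estimated change is a 1.2-fold higher number from compound 2 to compound 3 (0.09 log units; within the scatter). For compound 3 the expected value is 320 nM, within an estimated range of 130 nM to 800 nM.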

Compound 3, half-maximal inhibitory concentration: 1410 nM
The estimate for compound 3 lay 4.4-fold (0.64 log units) below the measured number; measured number above the stated range.
By their numbers in this assay, from the lowest: compounds 2 and 1 (each within the scatter of the next); then compound 3.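

In this assay the place on the aromatic ring, para to a large group, proves sensitive to the group it carries. Methylsulfonyl gives a 5.4-fold higher number from compound 2 to compound 3 (0.73 log units; beyond the scatter) and a 3.5-fold higher number from compound 1 to compound 3 (0.55 log units; beyond the scatter) while chloro and cyano had remained within the scatter of each other. The data at hand offer no explanation for this rise. The compounds shown leave open whether a methoxy group, an amine or a carboxylic acid at this place would stay close to chloro and cyano or move with methylsulfonyl. They also leave open whether methylthio, which lacks the two double bonds to oxygen, would do the same.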